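This account rests on a few compounds, and the source may have more. Where it says the series, first, only, none or still open, it means among the compounds named here.

Three compounds share one core, differing only in the group on the benzoyl ring: compound 1 `COc1ccc(C(=O)N/N=C/c2cc(I)cc(I)c2O)cc1`, compound 2 `CC(C)(C)c1ccc(C(=O)N/N=C/c2cc(I)cc(I)c2O)cc1` and compound 3 `O=C(N/N=C/c1cc(I)cc(I)c1O)c1ccc(Cl)cc1`. In a functional assay on HepG2 cells (Homo sapiens) for cytotoxicity, with a stated time of 24 h (a higher number here means a weaker inhibitor, a lower number a stronger inhibitor), compound 1 gives 45200 nM, compound 2 gives 41600 nM and compound 3 gives 14800 nM. The step of a 1.1-fold lower number from compound 1 to compound 2 (0.04 log units; within the scatter) shows nothing; the steps of a 3.1-fold lower number from compound 1 to compound 3 (0.48 log units; beyond the scatter) and a 2.8-fold lower number from compound 2 to compound 3 (0.45 log units; beyond the scatter) are both modest and point the same way. On these three numbers compound 3 stands lowest, separated from the other two beyond the scatter.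

Compound 4 `O=C(N/N=C/c1cc(I)cc(I)c1O)c1ccc(I)cc1` carries the change (iodo in place of chloro on an aromatic carbon). Among the compounds with values here, the two steps that bear on it both replace a group other than a halogen with chloro and lower the number modestly; no measured step exchanges one halogen for another. The expectation is therefore a step of a 1.3-fold lower number from compound 3 to compound 4 (0.13 log units; within the scatter), a small lowering that may well stay within the scatter. Compound 4 is estimated at 11000 nM in this assay, with a range from 5000 nM to 25000 nM.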

Compound 4, half-maximal inhibitory concentration: 31800 nM
Beside the measured number, compound 4's estimate is 2.9-fold (0.46 log units) below it, outside the stated range (above it).
By their numbers in this assay, from the lowest: compound 3; then compounds 4, 2 and 1 (each within the scatter of the next).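

In this assay this position does not treat the two halogens alike: the step of a 2.1-fold higher number from compound 3 to compound 4 (0.33 log units; beyond the scatter) is modest but beyond the scatter, so the low number of compound 3 goes with the 4-chlorophenyl group and not with halogen substitution as such. Iodo instead falls in with the non-halogen groups, since the steps of a 1.3-fold lower number from compound 2 to compound 4 (0.12 log units; within the scatter) and a 1.4-fold lower number from compound 1 to compound 4 (0.15 log units; within the scatter) both stay within the scatter, which leaves chloro as the only group shown that separates from the others. No measurement at hand bears on why chloro and iodo part here.

From the compounds shown here alone, whether bromo or fluoro on this aromatic carbon would group with chloro or with iodo stays open. So does what an amine or a carboxylic acid would give there.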